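Adding a Fluorine to a Benzothiophene Amide

The compounds below may be only part of what the source reports. "The series", "measured", "known", "first", "only" and "open" are said of these compounds alone.

Measured so far, in an assay on HEK293 cells for displacement of a labelled ligand from Urotensin-2 receptor (Homo sapiens), read by fluorescence, with a stated time of 90 min; a lower number here means a stronger inhibitor, a higher number a weaker inhibitor:
Compound 1, `O=C(NC1CCN(Cc2ccc(OC3CCNCC3)c(Br)c2)CC1)c1cccs1`, gives 130 nM.
Compound 2, `O=C(NC1CCN(Cc2ccc(OC3CCNCC3)c(Br)c2)CC1)c1cc2ccccc2s1`, gives 63 nM.

Compound 2 holds the lower of the two numbers in this assay, and the step of a 2.1-fold lower number from compound 1 to compound 2 (0.31 log units; beyond the scatter) lies beyond the scatter, so compound 2 is the stronger inhibitor of the pair. That step replaced the thiophen-2-yl group on the carbonyl carbon with the larger fused 1-benzothiophen-2-yl group.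

Compound 3, `O=C(NC1CCN(Cc2ccc(OC3CCNCC3)c(Br)c2)CC1)c1cc2cc(F)ccc2s1`, keeps the whole of compound 2 and differs only by fluoro in place of hydrogen on an aromatic carbon. Among the compounds with values here, no measured step shows how this assay responds to a fluoro group on the fused ring; the only step seen, from compound 1 to compound 2, concerned the ring system itself, not a substituent on it. With nothing to anchor the direction, the expectation is that compound 3 stays close to compound 2, with a step of a 1.1-fold lower number from compound 2 to compound 3 (0.06 log units; within the scatter) that is expected to remain within the scatter. Compound 3 is therefore estimated at 55 nM, in the range 20 nM to 150 nM.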

Compound 3, half-maximal inhibitory concentration: 53 nM
The estimate for compound 3 lay 1.0-fold (0.02 log units) above the measured number, within the range that was stated.
By their numbers in this assay, from the lowest: compounds 3 and 2 (each within the scatter of the next); then compound 1.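

In this assay, fluoro in place of hydrogen on the six-membered aromatic ring of the 1-benzothiophen-2-yl group gives a 1.2-fold lower number from compound 2 to compound 3 (0.08 log units; within the scatter), so the two compounds cannot be told apart by this measurement, and this carbon carries a fluoro group without a readable shift in the number. Within the data shown here, the earlier step concerned only the ring system, and this is the first look at a substituent on it. Set against the smaller thiophen-2-yl group, the 5-fluoro-1-benzothiophen-2-yl group gives a 2.5-fold lower number from compound 1 to compound 3 (0.39 log units; beyond the scatter), so the lower number seen with the fused ring system is kept with the fluoro group in place. No measurement is available that could explain why the number holds at this level.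

From the compounds shown here alone, a single fluorine is a very small change, so it remains open whether a larger group at the same carbon, such as a chlorine, a methoxy group or an amine, would leave the number where it is or move it. The compounds shown also do not tell how a fluoro group would behave on the other carbons of this ring, or on the thiophene part of the fused system.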